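Ethyl in Place of Acid Hydrogen: An Ester Expected Unchanged

The source may report more compounds than this note shows. Statements on the series, on what has been measured and on what is new or still open speak of the compounds shown alone.

Measured compounds:
Compound 1, `CCCCCCC(Sc1nc(Cl)cc(Oc2ccc3ncccc3c2)n1)C(=O)O`: in an assay for inhibition of Polyunsaturated fatty acid 5-lipoxygenase (Homo sapiens), tested at 1 uM (on this read-out higher numbers stand for a weaker effect at the one concentration tested and lower numbers for a stronger effect), compound 1 gives 93.7%.
Compound 2, `CCCCCCC(Sc1nc(Cl)cc(NCc2ccc3ncccc3c2)n1)C(=O)O`: in this assay compound 2 gives 95.6%.

Compound 1 shows the lowest of the two numbers, and compound 2 lies only a short distance higher, within the scatter, so the two cannot be told apart. Both sit near the top of the scale, where the effect is weak. Compound 3, `CCCCCCC(Sc1nc(Cl)cc(Oc2ccc3ncccc3c2)n1)C(=O)OCC`, arises from compound 1 by ethyl in place of hydrogen on an oxygen next to a carbonyl group. Among the measured compounds shown here, no step between measured compounds is available to guide the expectation. Since compound 1 is already near the top of the scale because of 93.7%, little room for change is expected. The step of a number 0.7 percentage points lower from compound 1 to compound 3 (within the scatter) is expected to stay within the scatter. Compound 3 is therefore estimated at 93%, between 80% and 102%.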

Compound 3, a percentage reported as activity, at one concentration (the size of the read-out at that concentration, not a potency): 79.1%
Compound 3: the middle estimate sits 13.9 percentage points above what was measured, outside the stated range (below it).
By their numbers in this assay, from the lowest: compound 3; then compounds 1 and 2 (each within the scatter of the next).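

Both earlier compounds carry the free carboxy group, so they could not show that this position responds at all. In this assay the change from carboxy to ethoxycarbonyl gives a number 14.6 percentage points lower from compound 1 to compound 3 (beyond the scatter) and moves the read-out toward a stronger effect, though compound 3 still stands high on the scale. Nothing available bears on the reason for this step.

From the compounds shown here alone, it remains open whether a methyl ester, a longer chain on this oxygen or an amide would give a step of similar size. Going by these compounds, it also remains open whether the same change on compound 2 would move its number in the same way.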